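The source may hold more compounds than are shown below. What is called first, only, known or untested is meant among the compounds shown, and "the series" means these compounds.

Among the compounds with values here, compound 2 `C/C(=C\C(=O)Nc1ccccc1OCCCC(=O)O)c1ccc2c(ccn2C(C(C)C)C(C)C)c1` gives 14 nM in an assay on Prostate gland for inhibition of steroid 5-alpha-reductase (Rattus norvegicus) (a higher number here means a weaker inhibitor, a lower number a stronger inhibitor), the lower of the two numbers measured so far, while compound 1 `CCCCCCCn1ccc2cc(/C(C)=C/C(=O)Nc3ccccc3OCCCC(=O)O)ccc21` gives 120 nM. Within the data shown here, the single measured step, an 8.6-fold lower number from compound 1 to compound 2 (0.93 log units; beyond the scatter), exchanges one group on the aromatic nitrogen for another, so this position clearly matters. Compound 3 `C/C(=C\C(=O)Nc1ccccc1OCCCC(=O)O)c1ccc2c(ccn2Cc2ccc(C)cc2)c1` alters the same position: 4-methylbenzyl in place of 1-isopropyl-2-methylpropyl on an aromatic nitrogen. Among the measured compounds shown here, no measured step shows how an aromatic ring attached there behaves, so a shift of comparable size in either direction remains possible, with a modest loss judged somewhat more likely. Compound 3 is therefore expected to give 30 nM, between 8 nM and 120 nM, an expected step of a 2.1-fold higher number from compound 2 to compound 3 (0.33 log units; beyond the scatter).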

Compound 3, half-maximal inhibitory concentration: 88 nM
Compound 3: middle estimate off by 2.9-fold (0.47 log units), on the low side; low and high end bracket the measured number.
By their numbers in this assay, from the lowest: compound 2; then compounds 3 and 1 (each within the scatter of the next).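

In this assay, the 4-methylbenzyl group gives up most of what 1-isopropyl-2-methylpropyl gained, with a 6.3-fold higher number from compound 2 to compound 3 (0.80 log units; beyond the scatter). Set against the straight heptyl chain, the ring-bearing group makes no clear difference, with a 1.4-fold lower number from compound 1 to compound 3 (0.13 log units; within the scatter), so at this position only the 1-isopropyl-2-methylpropyl group stands apart so far. Nothing measured here explains why these groups differ. A plain benzyl group or a cyclohexylmethyl group could show whether the methyl or the aromatic ring matters. As far as these compounds go, whether any other group on the aromatic nitrogen can match compound 2 also stays open.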